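The compounds below may be only part of what the source reports. "The series", "measured", "known", "first", "only" and "open" are said of these compounds alone.

Working notes on the shared core, which is the same in every compound here. Three compounds have been run in a functional assay on DU-145 cells (Homo sapiens) for antiproliferative activity, read by sulforhodamine B assay, with a stated time of 72 h; a lower number here means a stronger inhibitor, a higher number a weaker inhibitor. Compound 1, `O=C1CS/C(=N/Nc2nncc3ccccc23)N1c1ccccc1`, gives 97 nM in this assay. Compound 2, `NC(=S)NNc1nncc2ccccc12`, gives 65 nM. Compound 3, `Cc1cc(NS(=O)(=O)c2ccc(Nc3nncc4ccccc34)cc2)no1`, gives 35 nM, the lowest of the three numbers; its gap to compound 2 lies within the scatter, while its gap to compound 1 lies beyond it. Nothing in these numbers separates compound 3 from compound 2 by order.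

Compound 4, `O=S(=O)(Nc1ccccn1)c1ccc(Nc2nncc3ccccc23)cc1`, has not yet been measured. It differs from compound 3 in one place: pyridin-2-yl in place of 5-methyl-1,2-oxazol-3-yl on a sulfonamide nitrogen. Within the data shown here, no pair of measured compounds differs in a single place, so no measured step exists against which this change can be sized. Among the measured compounds shown here, the group on the sulfonamide nitrogen of compound 3 is the only example of that kind of variation, and the other two compounds carry no sulfonamide at all.

Compound 4 is expected to land close to compound 3 in this assay. The step of a 1.3-fold higher number from compound 3 to compound 4 (0.11 log units; within the scatter) is expected to stay within the scatter, with no direction that can be argued from the data. The estimate for compound 4 is 45 nM, with a range from 20 nM to 110 nM.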

Compound 4, half-maximal inhibitory concentration: 54 nM
The estimate for compound 4 lay 1.2-fold (0.08 log units) below the measured number, within the range that was stated.
By their numbers in this assay, from the lowest: compounds 3, 4, 2 and 1 (each within the scatter of the next, the first and the last beyond it).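

Pyridin-2-yl in place of 5-methyl-1,2-oxazol-3-yl on a sulfonamide nitrogen provides the first measured step in the series, a 1.5-fold higher number from compound 3 to compound 4 (0.19 log units; within the scatter), in this assay. At this position, a six-membered aromatic ring with 1 hetero atom can therefore stand in for a five-membered aromatic ring with 2 hetero atoms, both of 6 heavy atoms, with no difference that can be told from the scatter, and the pair cannot be put in order. No measurement bears on why the two groups read alike, and the result is recorded here without an explanation.

The compounds shown place only these two aromatic rings on the sulfonamide nitrogen, so this single step sets no rule for the position, and the outcome with a simple hydrogen, a methyl group, a cyclohexyl ring or an unsubstituted phenyl ring in the same place remains open. Going by these compounds, it also remains open whether a pyridin-2-yl ring carrying a methyl group, or one bearing a carboxylic acid or an amine, would stay as close to compound 3.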